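The source may hold more compounds than are shown below. What is called first, only, known or untested is meant among the compounds shown, and "the series" means these compounds.

Working notes on the series. Compound 1 `NCCCCN(C[C@H]1Cc2nccnc2CN1)[C@H]1CCCc2cccnc21` gives 50% in an ADME assay on microsomes from liver (Rattus norvegicus) for metabolic stability, using NADPH, with a stated time of 10 min; a higher number here means that more of the compound is left, a lower number that less of the compound is left. Compound 2 `NC(=O)NC/C=C/CN(C[C@H]1Cc2ncccc2CN1)[C@H]1CCCc2cccnc21` gives 1% in this assay, the lowest of the two numbers; the nearest is compound 1, a number higher by more than the scatter. Compound 3 `c1cnc2c(c1)CN[C@@H](CN(CCCC1CCNCC1)[C@H]1CCCc3cccnc31)C2` is not yet measured and differs from compound 2 in one place: a group of 8 heavy atoms (7 carbon, 1 nitrogen; one six-membered non-aromatic ring with 1 hetero atom) in place of a group of 7 heavy atoms (4 carbon, 2 nitrogen, 1 oxygen; no ring), on a saturated chain carbon bound to an amine nitrogen. Going by the values given here, no measured pair carries this change, so the step is an expectation only. An increase beyond the scatter is expected, a number 19 percentage points higher from compound 2 to compound 3 (beyond the scatter), because compound 1 gives 50%. For compound 3 the estimate in this assay is 20%, with a range from 3% to 55%.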

Compound 3, percent of the compound remaining: 40%
Compound 3: the middle estimate sits 20 percentage points below what was measured; the measured number falls inside the stated range.
By their numbers in this assay, from the lowest: compound 2; then compounds 3 and 1 (each within the scatter of the next).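

At this place, on a saturated chain carbon bound to an amine nitrogen, 2-(piperidin-4-yl)ethyl in place of the open-chain group gives a number 39 percentage points higher from compound 2 to compound 3 (beyond the scatter) in this assay on an otherwise unchanged core. Going by these compounds alone, this is the first change that can be read at a single place, and it shows that this position alone can move the read-out by a large step. No measurement bears on the reason for the step. It remains open whether the ring nitrogen of the piperidine matters, as a cyclohexyl group at this place is not among the compounds shown.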